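A few compounds are considered here, and "the series" means these few. Any claim that something is new, unique, unknown or untested is made for them only; others in the source may bear on it.

Measured so far in an ADME assay on the whole organism (Rattus norvegicus, strain Sprague-Dawley) for pharmacokinetics, using cassette dosing, at a dose of 0.5 mg/kg by the intravenous route; a higher number here means faster removal of the compound, a lower number slower removal:
Compound 1 `O=C(c1cc(-c2cn[nH]c2)on1)N1CCC(Cc2ccccc2)CC1` gives 71.6 mL/min/kg
Compound 2 `O=C(Nc1ccc2[nH]c(=O)oc2c1)C(=O)N1CCN(c2ccc(Cl)cc2)CC1` gives 7.2 mL/min/kg
Compound 3 `O=C1CCc2cc(NC(=O)C(=O)N3CCN(c4ccc(Cl)cc4)CC3)ccc2N1` gives "not determined" (no result reported)

Compound 2 stands lowest of the two numbers, with 7.2 mL/min/kg as its value, and compound 1 lies beyond the scatter from it, with 71.6 mL/min/kg as its value. Compound 3 offers no number for comparison.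

Compound 4 `O=C(Nc1ccc2[nH]c(=O)oc2c1)C(=O)N1CCN(c2ccc(F)c(F)c2)CC1` is not yet measured. It differs from compound 2 by 3,4-difluorophenyl in place of 4-chlorophenyl on an amine nitrogen in a ring and carries 3,4-difluorophenyl in place of 4-chlorophenyl on an amine nitrogen in a ring. For the measured compounds named here, no measured pair here shows a change of this kind, so the data give no direct guide to its size. The expectation therefore starts from compound 2 at 7.2 mL/min/kg and is for no step beyond the scatter in this assay with a slight rise at most. The expected step is a 1.3-fold higher number from compound 2 to compound 4 (0.10 log units; within the scatter) and it stays within the scatter. Compound 4 is estimated at 9 mL/min/kg with an expected range from 4 mL/min/kg to 20 mL/min/kg for its clearance.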

Compound 4, clearance: 4 mL/min/kg
For compound 4 the middle estimate is 2.3-fold (0.35 log units) above the measured one; the range from low to high includes it.
By their numbers in this assay, from the lowest: compounds 4 and 2 (each within the scatter of the next); then compound 1.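

In this assay, for the compounds shown here, the change to 3,4-difluorophenyl in place of 4-chlorophenyl on an amine nitrogen in a ring gives a 1.8-fold lower number from compound 2 to compound 4 (0.26 log units; within the scatter) and is the first step that can be read at this position. Compound 2 and compound 4 cannot be told apart on clearance, so this exchange of one halogenated phenyl group for another leaves the read-out within the usual scatter. Nothing at hand bears on the reason for this outcome.

One step on one core says little about how far this position tolerates change. On these data alone, whether a group of another kind at this place, such as a pyridine ring, a methoxy group on the phenyl ring or a carboxylic acid, would keep clearance in the same range remains open.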